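This account rests on a few compounds, and the source may have more. Where it says the series, first, only, none or still open, it means among the compounds named here.

The measured compounds in this set:

Compound 1, `Fc1ccc2nc(-c3ccccc3)nc(Nc3ccccc3)c2c1`, in a functional assay on HL-60 cells (Homo sapiens) for cytotoxicity, read by MTT assay, with a stated time of 48 h (on this read-out lower numbers stand for stronger inhibition and higher numbers for weaker inhibition), compound 1 gives > 50000 nM, which is a limit of the assay.
Compound 2, `COc1ccccc1Nc1nc(-c2cccc(F)c2)nc2ccc(F)cc12`, in this assay compound 2 gives > 50000 nM, which is also a limit of the assay.

Going by the values given here, compound 2 therefore stands at the limit of > 50000 nM in this assay, at which 2 of the 2 values shown sit, so no number for it is known, only that its value lies beyond the limit. Compound 1 sits at the same limit, and the pair shows no more than that both exceed it.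

Compound 3, `Fc1cccc(-c2nc(Nc3ccccc3F)c3cc(F)ccc3n2)c1`, has not been measured in this assay. It differs from compound 2 by fluoro in place of methoxy on an aromatic carbon. Among the compounds with values here, no step between measured compounds of this kind has been measured, so nothing here tells how such a change shifts the read-out. Given that compound 2 is already a limit in this assay, the account expects no step beyond the scatter and expects compound 3 most likely to come back as a limit as well; the expected step that the limit leaves unreadable from compound 2 to compound 3 is thus near zero. For compound 3 in this assay the estimate is 70000 nM, within a range from 25000 nM to 250000 nM.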

Compound 3, half-maximal inhibitory concentration: > 50000 nM
Compound 3: no number, only a limit; the forecaster's own chance of this, stated with the estimate: 80%; the middle value does not contradict the limit.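

In this assay compound 3 gives > 50000 nM, which is a limit of the assay. Going by these compounds alone, compound 2 sits at the same limit, so no step from compound 2 to compound 3 can be read for fluoro in place of methoxy. The compounds shown leave open which change to the shared core, if any, would yield an actual number: the limit of > 50000 nM in this assay, at which 3 of the 3 values shown sit.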